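The source may report more compounds than this note shows. Statements on the series, on what has been measured and on what is new or still open speak of the compounds shown alone.

Of the compounds shown here, three built on the shared core have been tested for cytotoxicity. Compound 1 `CSC(=O)c1c(O[C@@H]2O[C@H](CO)[C@@H](O)[C@H](O)[C@H]2O)c(C)c(O)c(C)c1C(C)C` was run in a functional assay on MDA-MB-231 cells (Homo sapiens) for cytotoxicity, read by sulforhodamine B assay, with a stated time of 72 h; a higher number here means a weaker inhibitor, a lower number a stronger inhibitor. In this assay compound 1 gives only a limit of the assay, > 40000 nM. Compound 2 `CCc1c(O)c(C)c(O[C@@H]2O[C@H](CO)[C@@H](O)[C@H](O)[C@H]2O)c(C(=O)SC)c1C(C)C` in this assay also gives only a limit, > 40000 nM. Compound 3 `CSC(=O)c1c(O[C@@H]2O[C@H](COC(C)=O)[C@@H](O)[C@H](O)[C@H]2O)c(C)c(O)c(C)c1C(C)C` in this assay likewise gives only a limit, > 40000 nM.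

Compound 2 and compound 1 differ by hydrogen in place of methyl on a saturated chain carbon bound to an aromatic carbon, and the step that the two limits leave unreadable from compound 2 to compound 1. Compound 1 and compound 3 differ by acetyl in place of hydrogen on an oxygen on a saturated carbon, and the step that the two limits leave unreadable from compound 1 to compound 3. The difference between the cores of compound 3 and compound 2 is not broken down here. For the measured compounds named here, all three measured values sit at the limit (the limit of > 40000 nM in this assay, at which 3 of the 3 values shown sit), so no measured step can be sized.

Compound 4 `CCc1c(C)c(O)c(C)c(O[C@@H]2O[C@H](COC(C)=O)[C@@H](O)[C@H](O)[C@H]2O)c1C(=O)SC` has not yet been measured. It differs from compound 3 by hydrogen in place of methyl on a saturated chain carbon bound to an aromatic carbon and a saturated chain carbon. Going by the values given here, this is the same kind of change as the one from compound 2 to compound 1, not the same: in compound 2 the saturated chain carbon is bound to an aromatic carbon, whereas in compound 3 it is bound to an aromatic carbon and a saturated chain carbon. The step from compound 3 to compound 4 in this assay is estimated as a step that the limit leaves unreadable from compound 3 to compound 4, set beside the earlier step that the two limits leave unreadable from compound 2 to compound 1, and this expectation rests on the limit of > 40000 nM in this assay, at which 3 of the 3 values shown sit, at which compound 3 sits. Compound 4 is expected to give 60000 nM, with a range from 20000 nM to 200000 nM.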

Compound 4, half-maximal inhibitory concentration: 16000 nM
For compound 4 the middle estimate is 3.8-fold (0.57 log units) above the measured one; measured number below the stated range.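

In this assay the change from isopropyl to ethyl on the core of compound 3 gives an at least 2.5-fold lower number from compound 3 to compound 4 (0.39 log units; beyond the scatter), and the size printed there is a lower bound, since the step starts from a limit of the assay. Compound 4, at 16000 nM, is the only compound shown with a measured number rather than a limit, so the series has one readable step, on one core carrying the acetyl group. This does not show that the change carries from one core to another: the same kind of change from compound 2 to compound 1 sits on a different carbon and, like the step from compound 1 to compound 3, cannot be read, so there is no second size to set against this one, and a single step makes no trend: the limit leaves the other compounds without a number, as the record shows: the limit of > 40000 nM in this assay, at which 3 of the 4 values shown sit.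

The compounds shown leave open whether a longer chain such as propyl, or an amine, in the place of the ethyl of compound 4 would move the number further in either direction. They also leave open what the same change from isopropyl to ethyl does on a core with a free hydroxyl in place of the acetyl ester.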